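Hydroxyacetamide series: aryl versus cyclopropylmethyl and clearance

The compounds below may be only part of what the source reports. "The series", "measured", "known", "first", "only" and "open" are said of these compounds alone.

Compound 1 `O=C(NCc1cc(Cl)ccc1-n1cnnn1)[C@@H]1C[C@@H]2C[C@@H]2N1C(=O)[C@H](O)c1ccccc1F` and compound 2 `O=C(NCc1cc(Cl)ccc1-n1cnnn1)[C@@H]1C[C@@H]2C[C@@H]2N1C(=O)[C@H](O)CC1CC1` share one core. In an ADME assay on liver for metabolic stability, with Liver microsome (Homo sapiens) as the target, read by LC-MS, using microsomes (on this read-out lower numbers stand for slow clearance and higher numbers for fast clearance), compound 1 reaches only the assay limit, < 12 mL.min-1.g-1. In this assay compound 2 likewise sits at the limit, < 12 mL.min-1.g-1. The step that the two limits leave unreadable from compound 1 to compound 2 is therefore not readable, as the limit of < 12 mL.min-1.g-1 in this assay, at which 2 of the 2 values shown sit, shows. Compound 3 `O=C(NCc1cc(Cl)ccc1-n1cnnn1)[C@@H]1C[C@@H]2C[C@@H]2N1C(=O)[C@H](O)c1ccccc1` differs from compound 2 by phenyl in place of cyclopropylmethyl on a saturated chain carbon bound to a carbonyl carbon and an oxygen on a saturated carbon. With both measured values at the limit, no sizeable step is expected beyond the scatter, and a step that the limit leaves unreadable from compound 2 to compound 3 is the estimated change. Compound 3 is expected near 8 mL.min-1.g-1 in this assay, between 3 mL.min-1.g-1 and 20 mL.min-1.g-1.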

Compound 3, intrinsic clearance in microsomes: < 16 mL.min-1.g-1
Compound 3 ended at the assay's limit; the forecaster's own chance of this, stated with the estimate: 70%; the middle value does not contradict the limit.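

In this assay compound 3 gives < 16 mL.min-1.g-1, a limit of the assay. Going by these compounds alone, with compound 1 and compound 2 also at limits, no step among the three can be read. As far as these compounds go, the actual clearance of each compound remains open.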